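Aromatic substituent change in the series

A few compounds are considered here, and "the series" means these few. Any claim that something is new, unique, unknown or untested is made for them only; others in the source may bear on it.

Three compounds of one shared core have been run: compound 1, `C/C(=N\OCC(=O)O)c1ccc(C2CC2)cc1`, compound 2, `C/C(=N\OCC(=O)O)c1ccc(O)cc1`, and compound 3, `COc1ccc(/C(C)=N/OCC(=O)O)cc1`. Compound 4, `C/C(=N\OCC(=O)O)c1ccc(N(C)C)cc1`, has not been measured. In a functional assay on the whole organism for inhibition, with Rattus norvegicus as the target, read by paw edema, with stated times of 1 h and 3 h, at a dose of 50 mg/kg by the oral route (on this read-out lower numbers stand for less inhibition and higher numbers for more inhibition at the one dose given (going by the name of the read-out)), compound 1 gives < 20%, which is a limit of the assay and not a number. In this assay compound 2 gives < 20%, likewise a limit. In this assay compound 3 gives < 20%, again a limit. Compound 3 thus stands where the whole measured set stands: the limit of < 20% in this assay, at which 3 of the 3 values shown sit. The steps a step that the two limits leave unreadable from compound 1 to compound 2, a step that the two limits leave unreadable from compound 1 to compound 3 and a step that the two limits leave unreadable from compound 2 to compound 3 are all unreadable; both ends of each sit at that limit.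

Compound 4 differs from compound 3 as follows: dimethylamino in place of methoxy on an aromatic carbon. Among the compounds with values here, no measured step gives a readable size for any change of the aromatic substituent, so nothing in this assay points in either direction beyond the scatter. Compound 4 is therefore expected to remain at the limit, with an expected step that the limit leaves unreadable from compound 3 to compound 4. The estimate for compound 4 is 12%, ranging from 0% to 30%.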

Compound 4, a percentage reported as inhibition, in the whole organism at one dose (the size of the read-out at that dose, not a potency): < 20%
Compound 4 was reported as a limit; the forecaster's own chance of this, stated with the estimate: 75%; the middle value is on the limit's open side.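

In this assay compound 4 gives < 20% as a limit of the assay and not a number. Within the data shown here, no step from compound 1, compound 2 or compound 3 to compound 4 can be read: the limit of < 20% in this assay, at which 4 of the 4 values shown sit. The compounds shown leave open whether any aromatic substituent on the shared core lifts this assay off that limit.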